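Inversion at the chain stereocentre of the ether series

The compounds below may be only part of what the source reports. "The series", "measured", "known", "first", "only" and "open" are said of these compounds alone.

Compound 1 `C[C@@H](O[C@H]1CCCN[C@H]1c1ccccc1)c1cc(C(F)(F)F)cc(C(F)(F)F)c1` is the most potent entry so far in a functional assay on microsomes from liver for antagonist activity at Substance-P receptor (Rattus norvegicus); on this read-out higher numbers stand for weaker inhibition and lower numbers for stronger inhibition: in this assay compound 1 gives 0.15 nM, the lowest of the two numbers in hand. Compound 2 `C[C@@H](O[C@H]1CCCN[C@H]1c1ccccc1)c1cc(Cl)cc(Cl)c1`, which carries chlorine in place of the two trifluoromethyl groups, gives 0.91 nM in this assay, a higher number that lies beyond the usual scatter. No stepwise comparison between measured pairs exists in this set, so the effect of a single structural change has not yet been observed directly.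

Compound 3 `C[C@H](O[C@H]1CCCN[C@H]1c1ccccc1)c1cc(C(F)(F)F)cc(C(F)(F)F)c1` is the epimer of compound 1: the two compounds have the same atoms and bonds and differ only in configuration as drawn: 1 of 3 stereo elements differ; a stereocentre at a saturated chain carbon is drawn R in compound 1 and S in compound 3. Both compounds share the same atoms and bonds; only the configuration at the saturated chain carbon changes. For a change of this kind a step well beyond the scatter is expected, toward weaker inhibition, since the relative arrangement of the aryl ether and the substituted core is altered. Compound 3 is therefore estimated at 15 nM in this assay, with a range from 2 nM to 150 nM, which corresponds to an expected step of a 100-fold higher number from compound 1 to compound 3 (2.00 log units; beyond the scatter).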

Compound 3, half-maximal inhibitory concentration: 87 nM
Beside the measured number, compound 3's estimate is 5.8-fold (0.76 log units) below it, and the stated range covers the measured number.
By their numbers in this assay, from the lowest: compound 1; then compound 2; then compound 3.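

In this assay, among these compounds, inverting the saturated chain carbon from R in compound 1 to S in compound 3 gives a 580-fold higher number from compound 1 to compound 3 (2.76 log units; beyond the scatter), the first single change in this set that can be read directly. The whole step can be assigned to this one stereocentre because no other difference separates the pair: the fact that compounds 1 and 3 differ only in the configuration as drawn. The configuration at this carbon is therefore a major determinant of the read-out for this pair with two trifluoromethyl groups, and R is the configuration with the lower number, though one pair does not establish a rule for the wider series.

Whether inversion at this carbon gives a step of similar size with the two chlorines of compound 2 remains open, as the compounds shown include only the R form of that aryl group. Also open, as far as these compounds go, is how much the substituent on the stereocentre itself contributes to the preference, which an ethyl group on the saturated chain carbon, in both configurations, would help to show.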